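Swapping isopropoxy for hydrogen on compound 1

A few compounds are considered here, and "the series" means these few. Any claim that something is new, unique, unknown or untested is made for them only; others in the source may bear on it.

Compound 1 `COc1ccc(C2=C(c3cc(OC)c(OC)c(OC)c3)C(=O)C(OC(C)=O)C2)cc1OC(C)C` gives > 100 ug/mL in an ADME assay on HEp-2 cells (Homo sapiens) for cytotoxicity, read by MTT assay, with a stated time of 72 h (on this read-out higher numbers stand for weaker inhibition and lower numbers for stronger inhibition), as a limit
Compound 2 `COc1ccc(C2=C(c3cc(OC)c(OC)c(OC)c3)C(=O)CC2C)cc1C(=O)O` gives > 100 ug/mL in this assay as a limit

Neither entry is a true number, so the account begins with limits alone. Compound 1 stands at > 100 ug/mL in this assay and this is a limit. Compound 2 stands at > 100 ug/mL and this too is a limit. The record so far is the limit of > 100 ug/mL in this assay, at which 2 of the 2 values shown sit, and no exact reading exists yet.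

Compound 3 `COc1ccc(C2=C(c3cc(OC)c(OC)c(OC)c3)C(=O)C(OC(C)=O)C2)cc1` carries hydrogen in place of isopropoxy on an aromatic carbon and is otherwise the same as compound 1. Among the compounds with values here, no measured pair shows what such a change does. The expectation in this assay is no step beyond the scatter in either direction, and it rests on compound 1, whose reading of > 100 ug/mL is a limit. The step expected is a step that the limit leaves unreadable from compound 1 to compound 3 by this estimate. For compound 3 the estimated value is 130 ug/mL with an expected range from 50 ug/mL to 350 ug/mL in this assay for now.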

Compound 3, half-maximal inhibitory concentration: 18 ug/mL
Estimate against measurement, compound 3: 7.2-fold (0.86 log units) above, and the stated range ends above it.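

Putting hydrogen in place of isopropoxy on this aromatic carbon gives an at least 5.5-fold lower number from compound 1 to compound 3 (0.74 log units; beyond the scatter) in this assay. Within the data shown here, compound 3 thus provides the first exact reading, and it shows that the substituent at this place, ortho to a methoxy group, can shift the read-out on the otherwise unchanged structure of compound 1. The full size of the step stays unknown because compound 1 rests on a limit and not on a number: the limit of > 100 ug/mL in this assay, at which 2 of the 3 values shown sit.

On these data alone, whether a hydroxyl group, an ethoxy group or an amine at this same place would read like hydrogen or like isopropoxy remains open. So does whether the same swap would give a similar step on any compound other than compound 1.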